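From iodo to ethynyl on the shared core

The compounds below may be only part of what the source reports. "The series", "measured", "known", "first", "only" and "open" are said of these compounds alone.

Compound 1 `C[C@]1(CO)O[C@@H](n2cc(I)c3c(N)ncnc32)[C@H](O)[C@@H]1O`: 27100 nM
Compound 2 `C[C@]1(CO)O[C@@H](n2cc(-c3ccsc3)c3c(N)ncnc32)[C@H](O)[C@@H]1O`: > 44000 nM (a limit)

Going by the values given here, in an ADME assay on Huh-7 cells (Homo sapiens) for cytotoxicity (on this read-out higher numbers stand for lower toxicity in this test and lower numbers for higher toxicity in this test), compound 1 gives 27100 nM, the only actual number so far. Compound 3 `C#Cc1cn([C@@H]2O[C@](C)(CO)[C@@H](O)[C@H]2O)c2ncnc(N)c12` is not yet measured and carries one change from compound 1: ethynyl in place of iodo on an aromatic carbon. Among the compounds with values here, the one measured step at this place is an at least 1.6-fold higher number from compound 1 to compound 2 (0.21 log units; that floor lies within the scatter), so it sets no clear direction. The expected outcome is a 1.1-fold lower number from compound 1 to compound 3 (0.04 log units; within the scatter), with no step beyond the scatter. For compound 3 the estimated value is 25000 nM, with an expected range of 9000 nM to 60000 nM.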

Compound 3, half-maximal cytotoxic concentration: 32300 nM
Estimate against measurement, compound 3: 1.3-fold (0.11 log units) below; measured number inside the range.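

In this assay, ethynyl in place of iodo gives a 1.2-fold higher number from compound 1 to compound 3 (0.08 log units; within the scatter), so this position now has a second actual number, and the change leaves it within the usual scatter. Replacing thiophen-3-yl with ethynyl gives an at least 1.3-fold lower number from compound 2 to compound 3 (0.13 log units; that floor lies within the scatter), which sets no clear direction either. The value of compound 2 is a limit, not a number: the limit of > 44000 nM in this assay, at which 1 of the 3 values shown sits.

On these data alone, whether an amine or a carboxylic acid on this aromatic carbon would move the number beyond the scatter remains open. So does the actual value of compound 2.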